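Swapping Methyl for tert-Butyl on a Shared Core

This account rests on a few compounds, and the source may have more. Where it says the series, first, only, none or still open, it means among the compounds named here.

Measured compounds:
- compound 1, `Cc1nnc2nnc(N3CCCC3)nn12`: 44800 nM
- compound 2, `Fc1ccc(-c2nnc3nnc(N4CCCC4)n3n2)cc1`: > 100000 nM (a limit, not a number)

Both compounds were tested in a functional assay on MCF7 cells (Homo sapiens) for cytotoxicity, read by MTT assay, with a stated time of 72 h; on this read-out higher numbers stand for weaker inhibition and lower numbers for stronger inhibition. In this assay compound 1 gives 44800 nM. Compound 2 reaches only > 100000 nM, which is a limit of the assay rather than a measured number. Among the compounds with values here, that leaves compound 1 as the only compound with an actual value, and the second entry in the table is the limit described as the limit of > 100000 nM in this assay, at which 1 of the 2 values shown sits.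

The next compound, compound 3, `CC(C)(C)c1nnc2nnc(N3CCCC3)nn12`, keeps the core of compound 1 and alters one group: tert-butyl in place of methyl on an aromatic carbon, in words, tert-butyl in place of methyl on an aromatic carbon. Within the data shown here, no measured pair in this set shows the effect of such a change, so the size of the step is open. With only compound 1 to anchor it, the expectation for this assay is a modest weakening, possibly no larger than the scatter, with a real chance that the assay again returns only a limit. Compound 3 is therefore estimated at 65000 nM, within 20000 nM to 200000 nM, a step of a 1.5-fold higher number from compound 1 to compound 3 (0.16 log units; within the scatter) expected from compound 1.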

Compound 3, half-maximal inhibitory concentration: 55000 nM
For compound 3 the middle estimate is 1.2-fold (0.07 log units) above the measured one, within the range that was stated.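

Within the data shown here, replacing methyl with tert-butyl on an aromatic carbon gives the first readable step at this position in this assay, and that step is a 1.2-fold higher number from compound 1 to compound 3 (0.09 log units; within the scatter). The group at this place grows from 1 heavy atom to 4 heavy atoms, yet the two compounds cannot be told apart on this read-out, so this one pair shows that a much bulkier carbon group can sit here without a difference larger than ordinary repeat measurements would give. Compound 3 also returns a real number, so two compounds on this core now have measured values, while the entry for compound 2 remains a limit and not a number: the limit of > 100000 nM in this assay, at which 1 of the 3 values shown sits.

From the compounds shown here alone, what stays open is whether a group of a different kind at this place, such as an amine or a carboxylic acid, would shift the number beyond the scatter. A single pair also cannot tell whether the same swap would behave the same way on a different core, or with a different group at the other substituted position of the shared core.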